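The source may hold more compounds than are shown below. What is called first, only, known or untested is meant among the compounds shown, and "the series" means these compounds.

Three small brominated catechol aldehydes and alcohols have been compared in a functional assay on DLD-1 cells (Homo sapiens) for cytotoxicity, read by MTT assay, with a stated time of 96 h; on this read-out lower numbers stand for stronger inhibition and higher numbers for weaker inhibition. Compound 1 `O=Cc1cc(Br)c(O)c(O)c1Br` gives 31000 nM. Compound 2 `O=Cc1cc(O)c(O)c(Br)c1Br` differs from compound 1 only in where the bromo groups sit on the shared core; in this assay compound 2 gives 30900 nM, which places compound 2 second highest of the three numbers, and its value is within the scatter of that of compound 1, so no order between the two can be claimed. Going by the values given here, compound 3 `OCc1cc(Br)c(O)c(O)c1Br` gives 15000 nM, and the single measured step of a 2.1-fold lower number from compound 1 to compound 3 (0.32 log units; beyond the scatter) is the only one in this set that lies beyond the scatter.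

The next compound, compound 4 `COCc1cc(O)c(O)c(Br)c1Br`, keeps the core and bromo pattern of compound 2 but carries a different group: methoxymethyl in place of formyl on an aromatic carbon. Among the compounds with values here, the one step that bears on this change is the one from compound 1 to compound 3, where a formyl was also exchanged for a saturated one-carbon side chain, and that exchange gave a modest lowering. A methoxymethyl is not a hydroxymethyl, so the parallel is loose, but it is the closest guide available; a step of similar size or smaller, a 1.5-fold lower number from compound 2 to compound 4 (0.19 log units; within the scatter), is therefore expected. Compound 4 is accordingly estimated at 20000 nM in this assay, within a range of 8000 nM to 50000 nM.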

Compound 4, half-maximal inhibitory concentration: 14600 nM
The estimate for compound 4 lay 1.4-fold (0.14 log units) above the measured number, within the range that was stated.
By their numbers in this assay, from the lowest: compounds 4 and 3 (each within the scatter of the next); then compounds 2 and 1 (each within the scatter of the next).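

On the aromatic carbon ortho to a bromo group and para to a hydroxy group, replacing formyl with methoxymethyl in this assay gives a 2.1-fold lower number from compound 2 to compound 4 (0.33 log units; beyond the scatter), a modest step but a real one. Going by these compounds alone, until now, the only step beyond the scatter came from the bromo pattern of compound 1, so this is the first sign that leaving the formyl can lower the number on the bromo pattern of compound 2 as well, and with an ether side chain rather than a hydroxymethyl. Formyl and methoxymethyl have the same hydrogen-bond donor and acceptor counts, yet the change removes a double bond outside the aromatic ring and adds a heavy atom, and no measurement here says why the number falls.

On these data alone, it remains open whether hydroxymethyl on the bromo pattern of compound 2, or methoxymethyl on that of compound 1, would give a step of the same kind. The same is true of a carboxylic acid, an aminomethyl group or a longer ether chain such as ethoxymethyl at this position, since the compounds shown include none of these groups.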